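Aryl variation at the carbonyl in a trimethoxyphenyl-pyrazole enone series

The compounds below may be only part of what the source reports. "The series", "measured", "known", "first", "only" and "open" are said of these compounds alone.

Measured compounds:
- compound 1, `COc1cc(-c2cc(/C=C/C(=O)c3ccc(Cl)c(Cl)c3)[nH]n2)cc(OC)c1OC`, 105%
- compound 2, `COc1ccc(C(=O)/C=C/c2cc(-c3cc(OC)c(OC)c(OC)c3)n[nH]2)cc1`, 101%

In a functional assay on OVCAR-3 cells (Homo sapiens) for cytotoxicity, read by sulforhodamine B assay, with a stated time of 48 h, tested at 0.1 uM (on this read-out higher numbers stand for a weaker effect at the one concentration tested and lower numbers for a stronger effect), compound 2 gives 101%, the lower of the two numbers at hand, while compound 1 gives 105%; the difference is within the scatter, so the two are indistinguishable and both show essentially no effect at the concentration tested.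

Compound 3, `COc1cc(-c2cc(/C=C/C(=O)c3ccc(F)c(F)c3)[nH]n2)cc(OC)c1OC`, is not yet measured. It differs from compound 2 in one place: 3,4-difluorophenyl in place of 4-methoxyphenyl on a carbonyl carbon. Within the data shown here, the only step that bears on it is the exchange of a dihalogenated aryl for the methoxylated one, a number 4 percentage points lower from compound 1 to compound 2 (within the scatter), which was within the scatter. Compound 3 returns to a dihalogenated aryl of the same substitution pattern as compound 1, so no step beyond the scatter is expected in this assay; the expected step of a number 2 percentage points higher from compound 2 to compound 3 (within the scatter) is small.

Compound 3 is therefore estimated at 103%, with a range from 92% to 114%.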

Compound 3, a percentage reported as activity, at one concentration (the size of the read-out at that concentration, not a potency): 104%
The estimate for compound 3 lay 1 percentage points below the measured number, within the range that was stated.
By their numbers in this assay, from the lowest: compounds 2, 3 and 1 (each within the scatter of the next).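

In this assay the 3,4-difluorophenyl group on the carbonyl carbon gives a number 3 percentage points higher from compound 2 to compound 3 (within the scatter) against 4-methoxyphenyl and a number 1 percentage points lower from compound 1 to compound 3 (within the scatter) against 3,4-dichlorophenyl, so all three aryl groups at this position are now indistinguishable. The series thus gains a second dihalogenated aryl, and exchanging chlorine for fluorine leaves the number as unmoved as exchanging either dihalogenated aryl for the methoxylated one, with all three compounds showing essentially no effect at the one concentration tested. No measurement at hand offers any explanation for this flat result.

The compounds shown leave open whether a 4-aminophenyl or a 4-carboxyphenyl group on the carbonyl carbon would move the number beyond the scatter. They also leave open whether compound 1, compound 2 and compound 3 would separate at a higher concentration.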